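The source may hold more compounds than are shown below. What is called first, only, known or untested is meant among the compounds shown, and "the series" means these compounds.

Compound 2, `C[C@H](NC(=O)[C@H](CCCNC(=N)N)NC(=O)c1ccc(CN(Cc2ccc(F)cc2)Cc2ccccn2)cc1)c1cccc2ccccc12`, was examined in an assay on Jurkat cells for displacement of a labelled ligand from C-X-C chemokine receptor type 4 (Homo sapiens), tested at 10 uM (a higher number here means more inhibition at the concentration tested (going by the name of the read-out), a lower number less inhibition), and gives 30%. Of the two compounds measured in this assay, compound 2 shows the highest number. For the measured compounds named here, the only other compound, compound 1, `C[C@@H](NC(=O)[C@H](CCCNC(=N)N)NC(=O)c1ccc(CN(Cc2ccccn2)C(=O)c2ccc(F)cc2)cc1)c1cccc2ccccc12`, gives 3% in this assay, a value that lies well below that of compound 2, by more than the usual spread between repeated measurements.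

Compound 3, `C[C@H](NC(=O)[C@H](CCCNC(=N)N)NC(=O)c1ccc(CN(Cc2ccccn2)C(=O)c2ccc(F)cc2)cc1)c1cccc2ccccc12`, has not yet been measured. Its structure differs from compound 2 in a single place: (4-fluorophenyl)carbonyl in place of 4-fluorobenzyl on an amine nitrogen. Going by the values given here, no pair of measured compounds differing in only one place is available, so the size of this particular step has not been observed directly.

The working expectation is that compound 3 will show less inhibition than compound 2 in this assay, with a step of a number 18 percentage points lower from compound 2 to compound 3 (beyond the scatter) that goes downward beyond the scatter. On that basis compound 3 is estimated to give about 12% in this assay, within a range from 0% to 35%, an estimate that awaits the measurement.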

Compound 3, a percentage reported as inhibition, at one concentration (the size of the read-out at that concentration, not a potency): 36%
Compound 3: middle estimate off by 24 percentage points, on the low side; measured number outside the range, above it.
By their numbers in this assay, from the lowest: compound 1; then compounds 2 and 3 (each within the scatter of the next).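

On the amine nitrogen, (4-fluorophenyl)carbonyl in place of 4-fluorobenzyl gives a number 6 percentage points higher from compound 2 to compound 3 (within the scatter) in this assay, so this read-out does not tell the two groups apart, even though the entering group carries a hydrogen-bond acceptor that the leaving group lacks. The stereocentre at a saturated chain carbon gives a far larger step, a number 33 percentage points higher from compound 1 to compound 3 (beyond the scatter), with the atoms and bonds otherwise the same, so within these two pairs the drawn configuration at that carbon counts for much more than the exchange on the nitrogen. The record describes what separates that pair in these terms: the fact that one of compounds 1 and 3 is drawn with a defined configuration and the other without, at the place where they differ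

As far as these compounds go, only these two groups on the amine nitrogen appear here, so it remains open how a smaller acetyl group, a methanesulfonyl group or a plain hydrogen at that place would read. It is also open whether the stereocentre carries the same weight with 4-fluorobenzyl on the nitrogen, and a reading at one concentration gives no potency for any of these compounds.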